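The compounds below may be only part of what the source reports. "The series", "measured", "known", "first", "only" and "open" are said of these compounds alone.

Working notes on the series. In a functional assay on RPMI 8402 cells (Homo sapiens) for cytotoxicity (on this read-out higher numbers stand for weaker inhibition and lower numbers for stronger inhibition), compound 1 `N#Cc1ccc2[nH]c(-c3ccc4[nH]c(-c5ccc6[nH]cnc6c5)nc4c3)nc2c1` gives > 25000 nM, which is a limit and not a number. Every step out of compound 1 therefore has only a bounded size.

Two measured steps start from it, both at the same aromatic carbon. With propyl in place of cyano, compound 2 `CCCc1ccc2[nH]c(-c3ccc4[nH]c(-c5ccc6[nH]cnc6c5)nc4c3)nc2c1` gives 7600 nM, and the step is an at least 3.2-fold lower number from compound 1 to compound 2 (0.51 log units; beyond the scatter). With pyridin-3-yl in place of cyano, compound 3 `c1cncc(-c2ccc3[nH]c(-c4ccc5[nH]c(-c6ccc7[nH]cnc7c6)nc5c4)nc3c2)c1` gives 35 nM, and the step is an at least 710-fold lower number from compound 1 to compound 3 (2.85 log units; beyond the scatter). The pyridin-3-yl group also outdoes propyl directly, with a 220-fold lower number from compound 2 to compound 3 (2.34 log units; beyond the scatter).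

Compound 4 `c1ccc(-c2ccc3[nH]c(-c4ccc5[nH]c(-c6ccc7[nH]cnc7c6)nc5c4)nc3c2)nc1` carries pyridin-2-yl in place of cyano on an aromatic carbon. The closest guide is the pyridin-3-yl change, since the entering group there is also a pyridinyl ring, and the propyl change is a much weaker guide. Going by the values given here, no pair compares pyridin-2-yl with pyridin-3-yl directly, so the range stays wide and leans towards weaker values than compound 3 shows.

A large move to a lower number is expected, with the estimated step being an at least 200-fold lower number from compound 1 to compound 4 (2.31 log units; beyond the scatter). The estimate for compound 4 is 120 nM, with an expected range from 25 nM to 1200 nM.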

Compound 4, half-maximal inhibitory concentration: 160 nM
Beside the measured number, compound 4's estimate is 1.3-fold (0.12 log units) below it; measured number inside the range.
By their numbers in this assay, from the lowest: compound 3; then compound 4; then compound 2. At a limit, above all of these: compound 1.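

In this assay, the two pyridinyl groups at this aromatic carbon are not interchangeable: pyridin-2-yl in place of pyridin-3-yl gives a 4.6-fold higher number from compound 3 to compound 4 (0.66 log units; beyond the scatter), so moving the ring nitrogen alone shifts the read-out, although by a modest step. Against propyl, pyridin-2-yl still gives a 48-fold lower number from compound 2 to compound 4 (1.68 log units; beyond the scatter), so in this small set the low numbers go with both pyridinyl groups and not with pyridin-3-yl alone. The step away from cyano is an at least 150-fold lower number from compound 1 to compound 4 (2.19 log units; beyond the scatter), and its true size stays unknown, since it is read against a limit: the limit of > 25000 nM in this assay, at which 1 of the 4 values shown sits.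

The compounds shown leave open whether the ring nitrogen is needed at all, which a phenyl group at this carbon would test, and where pyridin-4-yl would fall relative to the two pyridinyl groups. They also leave open whether a saturated ring such as piperidin-4-yl or morpholin-4-yl would share the low numbers, or whether an aromatic ring at this position is required.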